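The source may report more compounds than this note shows. Statements on the series, on what has been measured and on what is new or still open speak of the compounds shown alone.

Measured in the series:
- compound 1 `COc1ccc(CS(=O)(=O)/C=C/c2ccccc2OC)cc1`: 3500 nM
- compound 2 `COc1ccc(CS(=O)(=O)/C=C/c2ccc(F)cc2OC)cc1`: 10000 nM

In a functional assay on DU-145 cells (Homo sapiens) for antiproliferative activity, read by trypan blue exclusion (a higher number here means a weaker inhibitor, a lower number a stronger inhibitor), compound 1 holds the lowest of the two numbers; its nearest neighbour is compound 2, reached by a 2.9-fold higher number from compound 1 to compound 2 (0.46 log units; beyond the scatter). Compound 3 `COc1ccc(CS(=O)(=O)/C=C/c2c(OC)cccc2OC)cc1` differs from compound 1 by methoxy in place of hydrogen on an aromatic carbon. Among the measured compounds shown here, only the step from compound 1 to compound 2 bears on this change, and it concerns another group at another place, so it guides only loosely. The expected step is therefore small, at most modest, and more likely toward a higher number. Compound 3 is estimated at 5000 nM, range 1500 nM to 16000 nM, that is a 1.4-fold higher number from compound 1 to compound 3 (0.15 log units; within the scatter).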

Compound 3, half-maximal inhibitory concentration: 250 nM
Estimate against measurement, compound 3: 20-fold (1.30 log units) above; the whole stated range lies above it.
By their numbers in this assay, from the lowest: compound 3; then compound 1; then compound 2.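

In this assay methoxy in place of hydrogen on an aromatic carbon, ortho to a large group and meta to a methoxy group, gives a large step (a 14-fold lower number from compound 1 to compound 3 (1.15 log units; beyond the scatter)), so this position tolerates a substituent and the number falls sharply. Among the compounds shown here, the only earlier step (a 2.9-fold higher number from compound 1 to compound 2 (0.46 log units; beyond the scatter)) ran the other way, with fluoro at another place, so substitution on this ring has no single direction across these compounds. Nothing measured here accounts for the drop.

On these data alone, whether the drop is specific to methoxy at this position remains open. An ethoxy group, a hydroxyl or an amine at the same place would test that.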